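Compound 3: phenyl on the amine nitrogen

This account rests on a few compounds, and the source may have more. Where it says the series, first, only, none or still open, it means among the compounds named here.

Values in a functional assay on MCF7 cells (Homo sapiens) for antiproliferative activity; on this read-out higher numbers stand for weaker inhibition and lower numbers for stronger inhibition:
- compound 1 `CCN(CC)CCCOc1ccc2cc(NC(=O)c3ccc(O)c(CC=C(C)C)c3)c(=O)oc2c1C`: 6390 nM
- compound 2 `CC(C)=CCc1cc(C(=O)Nc2cc3ccc(OCCCN(C)C(C)(C)C)c(C)c3oc2=O)ccc1O`: 1140 nM

Compound 2, at 1140 nM, has the lower of the two numbers. Compound 3 `CC(C)=CCc1cc(C(=O)Nc2cc3ccc(OCCCN(C)c4ccccc4)c(C)c3oc2=O)ccc1O` differs from compound 2 by phenyl in place of tert-butyl on an amine nitrogen. Among the measured compounds shown here, the only measured step at this nitrogen is a 5.6-fold lower number from compound 1 to compound 2 (0.75 log units; beyond the scatter), a modest one involving a different exchange. For the measured compounds named here, no measurement yet covers phenyl here. A step of similar modest size is expected, more likely upward, though with little certainty. The expected step is a 2.1-fold higher number from compound 2 to compound 3 (0.32 log units; beyond the scatter). Compound 3 is estimated at 2400 nM, with an expected range of 800 nM to 7500 nM.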

Compound 3, half-maximal inhibitory concentration: > 50000 nM
Compound 3 was reported as a limit; the forecaster's own chance of this, stated with the estimate: 5%; at least 20-fold (1.31 log units) between middle value and limit.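

In this assay, phenyl in place of tert-butyl on the amine nitrogen gives an at least 43-fold higher number from compound 2 to compound 3 (1.64 log units; beyond the scatter) and so exceeds the modest earlier step at this nitrogen. Methyl(phenyl)amino in place of diethylamino gives an at least 7.8-fold higher number from compound 1 to compound 3 (0.89 log units; beyond the scatter) in the same direction, so both saturated amines shown stand clear of compound 3. The reading for compound 3 is a limit and not a number: the limit of > 50000 nM in this assay, at which 1 of the 3 values shown sits. From the compounds shown here alone, whether the drop follows from an aromatic ring directly on this nitrogen stays open. Cyclohexyl or benzyl at the same nitrogen would separate the two readings.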